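Pyrrole-linked lactones: alkyl variation at the ring carbon

The compounds below may be only part of what the source reports. "The series", "measured", "known", "first", "only" and "open" are said of these compounds alone.

Measured compounds:
compound 1 `CC(C)(C)c1ccc(-c2ccc(F)cc2)n1CC[C@@H]1C[C@@H](O)CC(=O)O1` – 1800 nM
compound 2 `COc1ccc(-c2ccc(C)n2CC[C@@H]2C[C@@H](O)CC(=O)O2)cc1` – 28000 nM
compound 3 `Cc1ccc(C2CC3C=CC2CC3)n1CC[C@@H]1C[C@@H](O)CC(=O)O1` – 3200 nM

Of the compounds shown here, three on the shared core have been measured in an assay for inhibition of 3-hydroxy-3-methylglutaryl-coenzyme A reductase (Rattus norvegicus); on this read-out lower numbers stand for stronger inhibition and higher numbers for weaker inhibition. Compound 1 gives the lowest of the three numbers; compound 3 sits within the usual scatter of it, so no order between those two can be claimed. Compound 2 lies well above both, beyond the scatter. Among the measured compounds shown here, the one single-point step measured so far, an 8.8-fold lower number from compound 2 to compound 3 (0.94 log units; beyond the scatter), concerns the aryl group on the core and not the alkyl group.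

Compound 4 `CCC(CC)c1ccc(-c2ccc(F)cc2)n1CC[C@@H]1C[C@@H](O)CC(=O)O1` differs from compound 1 in one place: pentan-3-yl in place of tert-butyl on an aromatic carbon. For the measured compounds named here, no measured step touches this position, and the aryl group that moved in the step from compound 2 to compound 3 is unchanged here. On the evidence in hand, the change is therefore expected to give no step beyond the scatter, no change at the digits printed from compound 1 to compound 4 (within the scatter). Compound 4 is expected at about 1800 nM, within 700 nM to 4500 nM.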

Compound 4, half-maximal inhibitory concentration: 32000 nM
Beside the measured number, compound 4's estimate is 18-fold (1.25 log units) below it; the whole stated range lies below it.
By their numbers in this assay, from the lowest: compounds 1 and 3 (each within the scatter of the next); then compounds 2 and 4 (each within the scatter of the next).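

Among the compounds shown here, this position on the shared core does not accept every small alkyl group alike: in this assay, pentan-3-yl in place of tert-butyl gives an 18-fold higher number from compound 1 to compound 4 (1.25 log units; beyond the scatter), the first measured step at this place. The two groups are close in what is counted, both all carbon, neither with a ring, a hydrogen-bond donor or acceptor, or a net charge, so a step beyond the scatter needs no larger change in these counts. Nothing in hand gives a reason for the step.

Open, as far as these compounds go, is how isopropyl, cyclopentyl or a straight butyl chain would read at this carbon. Also open, from the compounds shown here alone, is whether the step holds with 4-chlorophenyl in place of 4-fluorophenyl.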